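The source may hold more compounds than are shown below. What is called first, only, known or untested is meant among the compounds shown, and "the series" means these compounds.

Series notes. Compound 1 `CCc1nnc(SCc2ccccc2)n1N1C(=O)c2ccccc2C1=O` carries an ethyl group and a benzylsulfanyl group on the shared core. In a functional assay on HepG2 cells (Homo sapiens) for cytotoxicity, read by MTT assay, with a stated time of 48 h (a lower number here means a stronger inhibitor, a higher number a weaker inhibitor), compound 1 gives > 200000 nM, which is a limit of the assay rather than a number. Compound 2 `CCc1nnc(SCC(=O)c2ccccc2)n1N1C(=O)c2ccccc2C1=O` differs from compound 1 by benzoyl in place of phenyl on a saturated chain carbon bound to a sulfur. In this assay compound 2 gives > 200000 nM, again a limit. The result is a step that the two limits leave unreadable from compound 1 to compound 2. Compound 3 `COc1cc(-c2nnc(SCc3ccccc3)n2N2C(=O)c3ccccc3C2=O)cc(OC)c1OC` differs from compound 1 by 3,4,5-trimethoxyphenyl in place of ethyl on an aromatic carbon. In this assay compound 3 gives > 200000 nM, also a limit. Hence a step that the two limits leave unreadable from compound 1 to compound 3. All three sit at the limit of > 200000 nM in this assay, at which 3 of the 3 values shown sit. Compound 4 `COc1cc(-c2nnc(SCC(=O)c3ccccc3)n2N2C(=O)c3ccccc3C2=O)cc(OC)c1OC` is not yet measured; it differs from compound 3 by benzoyl in place of phenyl on a saturated chain carbon bound to a sulfur, the same change at the same place as from compound 1 to compound 2. The expected step that the limit leaves unreadable from compound 3 to compound 4 rests on both ends of that earlier change sitting at the limit of > 200000 nM in this assay, at which 3 of the 3 values shown sit. Compound 4 is expected to give 250000 nM, estimated between 100000 nM and 700000 nM, most likely reported only as a limit.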

Compound 4, half-maximal inhibitory concentration: 171000 nM
Beside the measured number, compound 4's estimate is 1.5-fold (0.16 log units) above it; the range from low to high includes it.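

On the core of compound 3, benzoyl in place of phenyl gives an at least 1.1-fold lower number from compound 3 to compound 4 (0.06 log units; that floor lies within the scatter) in this assay, and 3,4,5-trimethoxyphenyl in place of ethyl gives an at least 1.1-fold lower number from compound 2 to compound 4 (0.06 log units; that floor lies within the scatter). Among the compounds shown here, neither floor shows a real gain, and the earlier steps from compound 1 cannot be read, so the benzoyl change has no readable size on the core of compound 1 to set against its size on the core of compound 3. Whether the change carries from one core to the other therefore stays unshown, with compound 4 the only one holding a number: the limit of > 200000 nM in this assay, at which 3 of the 4 values shown sit.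

Open, as far as these compounds go, is whether an amine or a carboxylic acid on the benzoyl ring would give readable values in this assay. Also open, from the compounds shown here alone, is whether a longer chain in place of ethyl would do so.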